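Ethyl Ester in Place of Methyl: Expected Gain for Compound 4

This account rests on a few compounds, and the source may have more. Where it says the series, first, only, none or still open, it means among the compounds named here.

Compound 1, `COC(=O)c1ccc(-c2cc(N3CCC(CNS(N)(=O)=O)CC3)ncn2)cc1`: in a functional assay on M21 cells (Homo sapiens) for antiproliferative activity, read by sulforhodamine B assay, with a stated time of 48 h (on this read-out lower numbers stand for stronger inhibition of growth and higher numbers for weaker inhibition of growth), compound 1 gives 14100 nM.
Compound 2, `CCOC(=O)c1ccc(-c2cc(N3CCC(CNS(N)(=O)=O)CC3)ncn2)cc1`: compound 2 gives 5000 nM.
Compound 3, `COC(=O)c1ccc(-c2cc(N3CCC(CCNS(N)(=O)=O)CC3)ncn2)cc1`: compound 3 gives 19600 nM.

Compounds 1 and 2 share the same core and differ in one place only, (methyl in place of hydrogen on a saturated chain carbon bound to an oxygen next to a carbonyl group). That single change produced a step of a 2.8-fold lower number from compound 1 to compound 2 (0.45 log units; beyond the scatter), a modest but real improvement in growth inhibition.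

Compound 3 carries a slightly different core. Its difference from compound 1 is (sulfamoylamino)methyl in place of sulfamoylamino on a saturated chain carbon bound to a saturated ring carbon, and the step between them, a 1.4-fold higher number from compound 1 to compound 3 (0.14 log units; within the scatter), is within the usual scatter, so the two cores behave alike on this read-out as far as these numbers show.

Compound 4, `CCOC(=O)c1ccc(-c2cc(N3CCC(CCNS(N)(=O)=O)CC3)ncn2)cc1`, has not yet been measured. It differs from compound 3 by methyl in place of hydrogen on a saturated chain carbon bound to an oxygen next to a carbonyl group. For the measured compounds named here, this is the same change, at the same place, as the one from compound 1 to compound 2.

For compound 4 the step in this assay is expected to be about a 2.6-fold lower number from compound 3 to compound 4 (0.42 log units; beyond the scatter), placed beside the earlier 2.8-fold lower number from compound 1 to compound 2 (0.45 log units; beyond the scatter). This expectation rests on one measured pair only, and on the core of compound 3 tracking that of compound 1 within the scatter in a 1.4-fold higher number from compound 1 to compound 3 (0.14 log units; within the scatter). Going by the values given here, with only one precedent, the range must stay wide.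

Compound 4 is therefore estimated to give 7500 nM, expected to fall between 3000 nM and 18000 nM.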

Compound 4, concentration for 50% growth inhibition: 9000 nM
Compound 4: the middle estimate sits 1.2-fold (0.08 log units) below what was measured; the measured number falls inside the stated range.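

In this assay, the change from methoxycarbonyl to ethoxycarbonyl gave a 2.2-fold lower number from compound 3 to compound 4 (0.34 log units; beyond the scatter), so it lowered the number on the core of compound 3 as it had on the core of compound 1, and by a similar amount: the same change on two cores in this assay, a 2.8-fold lower number (0.45 log units; beyond the scatter) from compound 1 to compound 2 and a 2.2-fold lower number (0.34 log units; beyond the scatter) from compound 3 to compound 4, 1.3-fold (0.11 log units) apart, within the scatter of two such steps. The other change, (sulfamoylamino)methyl in place of sulfamoylamino, now also has a second reading, a 1.8-fold higher number from compound 2 to compound 4 (0.26 log units; within the scatter), and it stays within the scatter on the ethyl esters as it did on the methyl esters: the same change on two cores in this assay, a 1.4-fold higher number (0.14 log units; within the scatter) from compound 1 to compound 3 and a 1.8-fold higher number (0.26 log units; within the scatter) from compound 2 to compound 4, 1.3-fold (0.11 log units) apart, within the scatter of two such steps. These two pairs show that, in this one assay, the ester change carried over between two closely related cores, but they do not show that it would carry over to a more different core, and they say nothing about why the ethyl ester gives the lower number.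

The compounds shown leave open whether growth inhibition would keep improving with a propyl or isopropyl ester, or what a carboxylic acid or an amide would do in place of the ester. On these data alone, it also remains open how a still longer chain carrying the sulfamoylamino group would behave, with either the methyl or the ethyl ester.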